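Bromocoumarin triazoles: swapping the linking atom in the side chain

A few compounds are considered here, and "the series" means these few. Any claim that something is new, unique, unknown or untested is made for them only; others in the source may bear on it.

Measured so far:
compound 1 `O=c1cc(-n2cc(-c3ccccc3)nn2)c2cc(Br)ccc2o1`, 11200 nM
compound 2 `O=c1cc(-n2cc(CNc3ccccc3)nn2)c2cc(Br)ccc2o1`, 13200 nM
compound 3 `O=c1cc(-n2cc(CSc3ccccc3)nn2)c2cc(Br)ccc2o1`, 3510 nM

In a functional assay on A549 cells (Homo sapiens) for antiproliferative activity, read by MTT assay, with a stated time of 48 h (a lower number here means a stronger inhibitor, a higher number a weaker inhibitor), compound 3 gives the lowest number of the three; compound 1 stands a 3.2-fold lower number from compound 1 to compound 3 (0.50 log units; beyond the scatter) and compound 2 a 3.8-fold lower number from compound 2 to compound 3 (0.58 log units; beyond the scatter), both beyond the scatter. Compounds 1 and 2 are within the scatter of each other: a 1.2-fold higher number from compound 1 to compound 2 (0.07 log units; within the scatter).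

Compound 4 `O=c1cc(-n2cc(COc3ccccc3)nn2)c2cc(Br)ccc2o1` differs from compound 3 by phenoxy in place of phenylsulfanyl on a saturated chain carbon bound to an aromatic carbon. Among the compounds with values here, no measured step changes the linking atom from sulfur to oxygen. Within the data shown here, the only step that changes the atom in that place is from compound 2 to compound 3, a 3.8-fold lower number from compound 2 to compound 3 (0.58 log units; beyond the scatter), where the anilino link gave the weaker number. Compound 1, with no linking chain at all, also sits well above compound 3. On this basis the expectation for compound 4 is a modestly higher number than compound 3 in this assay, a 2.0-fold higher number from compound 3 to compound 4 (0.30 log units; within the scatter), since the sulfur link is the only one so far that has given the lower number. Compound 4 is therefore estimated at 7000 nM, in a range from 2500 nM to 20000 nM.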

Compound 4, half-maximal inhibitory concentration: 12300 nM
Estimate against measurement, compound 4: 1.8-fold (0.24 log units) below; the measured number falls inside the stated range.
By their numbers in this assay, from the lowest: compound 3; then compounds 1, 4 and 2 (each within the scatter of the next).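

In this assay, a 3.5-fold higher number from compound 3 to compound 4 (0.54 log units; beyond the scatter) shows that this position responds to the linking atom alone: phenoxy in place of phenylsulfanyl leaves the ring and the counts of heavy atoms, donors and acceptors unchanged, yet the step lies beyond the scatter. The oxygen link cannot be told apart from the nitrogen link, a 1.1-fold lower number from compound 2 to compound 4 (0.03 log units; within the scatter), nor from the directly attached phenyl, a 1.1-fold higher number from compound 1 to compound 4 (0.04 log units; within the scatter), so among the four compounds only the phenylsulfanyl of compound 3 stands apart. No measurement at hand accounts for this difference between the linking atoms.

As far as these compounds go, whether a sulfoxide or sulfone at the linking atom, or a longer chain carrying the sulfur, would keep the lower number remains open. So does whether the sulfur-to-oxygen step keeps its size with a chloro or methoxy group on the phenyl ring.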